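Ester to free acid: a step with little precedent

The source may hold more compounds than are shown below. What is called first, only, known or untested is meant among the compounds shown, and "the series" means these compounds.

Measured in a functional assay on HCT-116 cells (Homo sapiens) for inhibition, read by MTT assay, with a stated time of 2 days, tested at 10 uM; on this read-out higher numbers stand for more inhibition at the one concentration tested (going by the name of the read-out) and lower numbers for less inhibition:
- compound 1 `COc1ccccc1-c1cn(-c2ccc(O)c(C(=O)Nc3cccc(C(F)(F)F)c3)c2)nn1`: 61%
- compound 2 `COc1ccccc1-c1cn(-c2ccc(O)c(C(=O)OCCCc3ccccc3)c2)nn1`: 7%

Going by the values given here, compound 2 stands at the lower of the two numbers; the only measured step, a number 54 percentage points lower from compound 1 to compound 2 (beyond the scatter), is the replacement on the same carbonyl carbon. Compound 3 `COc1ccccc1-c1cn(-c2ccc(O)c(C(=O)O)c2)nn1` differs from compound 2 by hydrogen in place of 3-phenylpropyl on an oxygen next to a carbonyl group. No measured step covers an ester to a free acid, so the one step shown gives no direct guide to the direction. With compound 2 already at the low end, the change from compound 2 to compound 3 is expected to give no step beyond the scatter, a number 1 percentage points higher from compound 2 to compound 3 (within the scatter). Compound 3 is estimated at 8%, in the range 0% to 25%.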

Compound 3, a percentage reported as inhibition, at one concentration (the size of the read-out at that concentration, not a potency): 4%
Compound 3: middle estimate off by 4 percentage points, on the high side; the measured number falls inside the stated range.
By their numbers in this assay, from the lowest: compounds 3 and 2 (each within the scatter of the next); then compound 1.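

Working notes: in this assay, hydrogen in place of 3-phenylpropyl on an oxygen next to a carbonyl group leaves the ester and free acid indistinguishable (a number 3 percentage points lower from compound 2 to compound 3 (within the scatter)). The free acid also stands well apart from the amide (a number 57 percentage points lower from compound 1 to compound 3 (beyond the scatter)), so among the three groups shown on this carbonyl carbon, only (3-(trifluoromethyl)phenyl)amino goes with a substantial number. Nothing available bears on the cause of these numbers.

Open: whether 3-phenylpropylamino on the same carbonyl carbon would track with the amide or the ester. Phenylamino without the trifluoromethyl group would test the part played by that substituent.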